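Methoxy on the Second Ring of a Bis-amidine Benzofuran

The source may hold more compounds than are shown below. What is called first, only, known or untested is meant among the compounds shown, and "the series" means these compounds.

Compounds 1, 2 and 3 share a core carrying two amidine-type groups. Compound 1 `CC(C)NC(=N)c1ccc(-c2cc3cc(C(=N)NC(C)C)ccc3o2)cc1` and compound 3 `COc1cc(C(=N)NC(C)C)ccc1-c1cc2cc(C(=N)NC(C)C)ccc2o1` differ in one place: methoxy in place of hydrogen on an aromatic carbon. Compound 2 `N=C(N)c1cccc(-c2cc3cc(C(=N)N)ccc3o2)c1` differs from compound 1 in more than one place, and that difference between the two cores is not broken down here. Compound 4 `COc1ccc(C(=N)N)cc1-c1cc2cc(C(=N)N)ccc2o1` is not yet measured; it differs from compound 2 by methoxy in place of hydrogen on an aromatic carbon.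

In an ADME assay on L6 cells (Rattus norvegicus) for cytotoxicity (a lower number here means a stronger inhibitor, a higher number a weaker inhibitor), compound 1 reaches only the limit of the assay, > 198000 nM, so no number is known for it; (the limit of > 198000 nM in this assay, at which 1 of the 3 values shown sits). Compound 3 gives 98100 nM, which is an at least 2.0-fold lower number from compound 1 to compound 3 (0.30 log units; that floor lies within the scatter). Compound 2 gives 21200 nM, a lower number than compound 3 by a gap beyond the usual scatter.

The change from compound 2 to compound 4 is the same kind of change as from compound 1 to compound 3, but its surroundings differ: in compound 3 the methoxy sits meta to a group of 6 heavy atoms, in compound 4 para to a group of 3 heavy atoms. Resting on the step from compound 1 to compound 3, compound 4 is expected to show a 2.1-fold lower number from compound 2 to compound 4 (0.33 log units; beyond the scatter) in this assay, that is an estimated 10000 nM, between 4000 nM and 40000 nM.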

Compound 4, half-maximal inhibitory concentration: 179000 nM
Beside the measured number, compound 4's estimate is 18-fold (1.25 log units) below it, and the stated range ends below it.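

In this assay, methoxy in place of hydrogen on an aromatic carbon gives an 8.4-fold higher number from compound 2 to compound 4 (0.93 log units; beyond the scatter), so on this core the change moves the number up, towards a weaker inhibitor. Set beside the earlier step, the same change does not carry over as one fixed shift from core to core: the same change on two cores in this assay, an at least 2.0-fold lower number (0.30 log units; that floor lies within the scatter) from compound 1 to compound 3 and an 8.4-fold higher number (0.93 log units; beyond the scatter) from compound 2 to compound 4, at least 17-fold (1.23 log units) apart, beyond the scatter of two such steps With only two cores, and with the methoxy in different surroundings on each, this does not show whether the core or the place of the methoxy sets the outcome, and compound 1 gives only a limit of the assay, > 198000 nM, not a number.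

Going by these compounds, it remains open whether the rise on the core of compound 2 belongs to methoxy alone or would also appear with a hydroxyl or an ethoxy on the same carbon. Also open, on these data alone, is how methoxy would behave on each core if it held the place it has on the other.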